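The source may report more compounds than this note shows. Statements on the series, on what has been measured and on what is new or still open speak of the compounds shown alone.

Measured so far in an assay on isolated protein for binding affinity to transient receptor potential cation channel subfamily V member 1 (Rattus norvegicus); a lower number here means a stronger inhibitor, a higher number a weaker inhibitor:
compound 1 `COc1cc(CNC(=S)NCC(COC(=O)C(C)(C)C)Cc2ccc(C)c(C)c2)ccc1O`: 17.4 nM
compound 2 `Cc1ccc(CC(CN/C(S)=N/Cc2ccc(NS(C)(=O)=O)cc2)COC(=O)C(C)(C)C)cc1C`: 29.3 nM
compound 3 `Cc1ccc(CC(CN/C(S)=N/Cc2ccc(NS(=O)(=O)c3ccccc3)cc2)COC(=O)C(C)(C)C)cc1C`: 2500 nM

Compound 2 holds the second highest of the three numbers. Its nearest neighbour is compound 1, which sits within the scatter of compound 2, so the two cannot be told apart. Going by the values given here, compound 3 lies far off: the step of an 85-fold higher number from compound 2 to compound 3 (1.93 log units; beyond the scatter) is the only measured step between compounds differing in one place, and it is large and well beyond the scatter.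

Compound 4 `Cc1ccc(CC(CN/C(S)=N/Cc2cccc(NS(C)(=O)=O)c2)COC(=O)C(C)(C)C)cc1C` is not yet measured. It differs from compound 2 as follows: 3-(methanesulfonamido)phenyl in place of 4-(methanesulfonamido)phenyl on a saturated chain carbon bound to a double-bonded nitrogen. Among the compounds with values here, the single measured step, an 85-fold higher number from compound 2 to compound 3 (1.93 log units; beyond the scatter), concerns a different change, phenyl in place of methyl on a sulfonyl sulfur, and does not bear on exchanging 4-(methanesulfonamido)phenyl for 3-(methanesulfonamido)phenyl; no measured pair shows that exchange. The expectation therefore rests on the structural change alone: a modest step toward a higher number is expected, a 2.0-fold higher number from compound 2 to compound 4 (0.31 log units; beyond the scatter), though a step within the scatter cannot be ruled out. Compound 4 is estimated at 60 nM, expected to fall between 15 nM and 250 nM.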

Compound 4, inhibition constant: 355 nM
Compound 4: middle estimate off by 5.9-fold (0.77 log units), on the low side; the whole stated range lies below it.
By their numbers in this assay, from the lowest: compounds 1 and 2 (each within the scatter of the next); then compound 4; then compound 3.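

In this assay, exchanging 4-(methanesulfonamido)phenyl for 3-(methanesulfonamido)phenyl gives a 12-fold higher number from compound 2 to compound 4 (1.08 log units; beyond the scatter), although the two groups contain the same atoms, joined differently. Going by these compounds alone, the number therefore depends on how the methanesulfonamido group is joined to the phenyl ring, as well as on what is carried on the sulfonyl sulfur, the only change with a measured step until now. No available evidence accounts for the size of this step.

Still open is whether the same exchange has a step of similar size when phenyl replaces methyl on the sulfonyl sulfur, as only the methyl pair is shown. Also open, on these data alone, is how a carboxylic acid or an amine would compare with the methanesulfonamido group on this phenyl ring.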